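Quinoline series: fluoro for trifluoromethyl on the pendant aryl

This account rests on a few compounds, and the source may have more. Where it says the series, first, only, none or still open, it means among the compounds named here.

Compound 1 `FC(F)(F)c1ccc(/C=C\c2cc3ccc(Cl)cc3nc2Cl)cc1` gives 16100 nM in a functional assay on MDA-MB-468 cells (Homo sapiens) for antiproliferative activity, read by sulforhodamine B assay, with a stated time of 72 h; a lower number here means a stronger inhibitor, a higher number a weaker inhibitor. Compound 2 `Fc1ccc(/C=C\c2cc3ccc(Cl)cc3nc2Cl)cc1` carries the change fluoro in place of trifluoromethyl on an aromatic carbon and gives 10900 nM; the step is a 1.5-fold lower number from compound 1 to compound 2 (0.17 log units; within the scatter). Compound 3 `COc1ccc2nc(Cl)c(/C=C\c3ccc(C(F)(F)F)cc3)cc2c1` has a different core; the difference between the two cores is not broken down here. Compound 3 gives 22700 nM, within the scatter of compound 1 and a larger number than compound 2.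

Compound 4 `COc1ccc2nc(Cl)c(/C=C\c3ccc(F)cc3)cc2c1` is the not yet measured partner of compound 3. It carries the change (fluoro in place of trifluoromethyl on an aromatic carbon), the same change as that from compound 1 to compound 2, at the same place. That one measured instance of the change gave a small step lying within the scatter, so the expectation for compound 4 is a step of a 1.5-fold lower number from compound 3 to compound 4 (0.18 log units; within the scatter), resting on a 1.5-fold lower number from compound 1 to compound 2 (0.17 log units; within the scatter) and on the value of compound 3, 22700 nM. On this basis compound 4 is estimated at 15000 nM, expected to lie between 7000 nM and 32000 nM, with a single precedent carrying the estimate.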

Compound 4, half-maximal inhibitory concentration: 15200 nM
The estimate for compound 4 lay 1.0-fold (0.01 log units) below the measured number; the measured number falls inside the stated range.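

In this assay, fluoro in place of trifluoromethyl on the core of compound 3 gives a 1.5-fold lower number from compound 3 to compound 4 (0.17 log units; within the scatter), and this step agrees with the one seen on the core of compound 1: the same change on two cores in this assay, a 1.5-fold lower number (0.17 log units; within the scatter) from compound 1 to compound 2 and a 1.5-fold lower number (0.17 log units; within the scatter) from compound 3 to compound 4, 1.0-fold (0.00 log units) apart, within the scatter of two such steps. In these two pairs, then, the change carries from one core to the other with no difference in size that stands out from the scatter. Both steps themselves lie within the scatter, however, so the agreement is one between two small steps: neither pair separates fluoro from trifluoromethyl in this assay, and two cores cannot show how the change would behave on a third or how a change with a larger step would carry over.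

Open, from the compounds shown here alone, is whether any group at this place, on an aromatic carbon para to a large group, would give a step beyond the scatter, for instance an amine, a carboxylic acid or a longer chain. Also open, going by these compounds, is how the two cores compare with each other, and whether the agreement between the two steps holds in other cell lines.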